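Weak cytotoxicity and a hydroxy step from compound 1

A few compounds are considered here, and "the series" means these few. Any claim that something is new, unique, unknown or untested is made for them only; others in the source may bear on it.

In a functional assay on MCF7 cells (Homo sapiens) for cytotoxicity, read by MTT assay, with a stated time of 5 days (a lower number here means a stronger inhibitor, a higher number a weaker inhibitor), compound 1 (`Nc1n[nH]c(=O)c2c1ncn2[C@H]1C[C@H](O)[C@@H](CO)O1`) gives > 100000 nM, which is a limit of the assay and not a number. The isomeric compound 2 (`Nc1n[nH]c(=O)c2ncn([C@H]3C[C@H](O)[C@@H](CO)O3)c12`) gives 97500 nM, so it has a measured number, though a high one. Compound 3 (`Nc1n[nH]c(=O)c2c1ncn2[C@@H]1O[C@H](CO)[C@@H](O)[C@H]1O`) differs from compound 1 by hydroxy in place of hydrogen on a saturated ring carbon. Within the data shown here, no measured step in this assay covers this change, and with compound 2 at 97500 nM only a small move toward stronger inhibition is expected. The expected step is an at least 1.2-fold lower number from compound 1 to compound 3 (0.09 log units; that floor lies within the scatter). Compound 3 is estimated at 80000 nM, with an expected range of 20000 nM to 200000 nM.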

Compound 3, half-maximal inhibitory concentration: 27500 nM
Estimate against measurement, compound 3: 2.9-fold (0.46 log units) above, within the range that was stated.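

In this assay, hydroxy in place of hydrogen on this saturated ring carbon gives an at least 3.6-fold lower number from compound 1 to compound 3 (0.56 log units; beyond the scatter), so this position of the five-membered ring can move the cytotoxicity read-out. Compound 1 gives > 100000 nM, which is a limit of the assay and not a number. The step is therefore a floor, and its full size stays unknown because it starts from that limit: the limit of > 100000 nM in this assay, at which 1 of the 3 values shown sits.

On these data alone, whether an amine or a fluorine atom on the same carbon would move the number as hydroxy does stays open. Also open, as far as these compounds go, is whether the hydroxy step carries over to the isomeric compound 2.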